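Cytotoxicity notes: ring size change on the amide-borne radical group

A few compounds are considered here, and "the series" means these few. Any claim that something is new, unique, unknown or untested is made for them only; others in the source may bear on it.

Of the compounds shown here, two have been measured in a functional assay on MCF7 cells (Homo sapiens) for cytotoxicity, read by MTT assay, with a stated time of 72 h; a higher number here means a weaker inhibitor, a lower number a stronger inhibitor. Compound 1 `Cc1c(C)c2c(c(C)c1OC(=O)CCC(=O)NC1CC(C)(C)N([O])C(C)(C)C1)CCC(C)(C(=O)NC1CC(C)(C)N([O])C(C)(C)C1)O2` carries the same kind of group on both of its amide nitrogens; compound 1 gives 62000 nM. Compound 2 `Cc1c(C)c2c(c(C)c1OC(=O)CCC(=O)NC1CC(C)(C)N([O])C(C)(C)C1)CC[C@@](C)(CCC[C@H](C)CCC[C@H](C)CCCC(C)C)O2` keeps one such amide and replaces the other with a long saturated chain. Compound 2 reaches only a limit of the assay, > 300000 nM, and so no number is known for it; this is the limit described by the limit of > 300000 nM in this assay, at which 1 of the 2 values shown sits, and compound 2 stands at the weak end of what the series has shown so far. For the measured compounds named here, the two values therefore differ, but no step between them can be sized.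

Compound 3 `Cc1c(C)c2c(c(C)c1OC(=O)CCC(=O)NCC1CC(C)(C)N([O])C1(C)C)CC[C@@](C)(CCC[C@H](C)CCC[C@H](C)CCCC(C)C)O2` differs from compound 2 only in the group on the amide nitrogen: a group of 11 heavy atoms (9 carbon, 1 nitrogen, 1 oxygen; one five-membered non-aromatic ring with 1 hetero atom) in place of a group of 11 heavy atoms (9 carbon, 1 nitrogen, 1 oxygen; one six-membered non-aromatic ring with 1 hetero atom), on an amide-type nitrogen. Nothing measured in the series speaks to this change, so no direction can be drawn from a known step. Given that compound 2 already sits at the limit, compound 3 is expected to remain weak, with a step of a number no higher from compound 2 to compound 3 (the limit leaves the size open) that is not expected to exceed the scatter. Compound 3 is estimated at 300000 nM, within a range from 100000 nM to 1000000 nM, and a further limit rather than a number is the more likely outcome.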

Compound 3, half-maximal inhibitory concentration: 260000 nM
Estimate against measurement, compound 3: 1.2-fold (0.06 log units) above, within the range that was stated.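

In this assay, for the compounds shown here, compound 3 gives 260000 nM, the first actual number for a compound with the long saturated chain on the shared core. Compound 2 gives only a limit of the assay, > 300000 nM, and not a number. Placing the group with one five-membered non-aromatic ring with 1 hetero atom on the amide-type nitrogen, in place of the group with one six-membered non-aromatic ring with 1 hetero atom, gives an at least 1.1-fold lower number from compound 2 to compound 3 (0.06 log units; that floor lies within the scatter), and the real size of that step remains unknown because one end of it is a limit: the limit of > 300000 nM in this assay, at which 1 of the 3 values shown sits.

The series shown therefore does not establish whether ring size on this amide-type nitrogen matters to the read-out, and a pair in which both partners give numbers would be needed to settle that. Also open, going by these compounds, is how the same ring change would read with the second amide of compound 1 in place of the long saturated chain, and how a simple amine or a carboxylic acid would read on the amide nitrogen in place of either ring group.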